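The compounds below may be only part of what the source reports. "The series", "measured", "known", "first", "only" and "open" are said of these compounds alone.

Measured in a functional assay on DWD cells (Homo sapiens) for inhibition, read by sulforhodamine B assay; a lower number here means a stronger inhibitor of growth, a higher number a weaker inhibitor of growth:

Compound 1 `Fc1ccc(-c2ccc(-c3ccc(-c4nc5ccccc5[nH]4)cc3)cc2)cc1`: 35600 nM
Compound 2 `FC(F)(F)Oc1ccc(-c2ccc(-c3ccc(-c4nc5ccccc5[nH]4)cc3)cc2)cc1`: 100000 nM
Compound 3 `Oc1cccc2[nH]c(-c3ccc(-c4ccc(-c5ccc(F)cc5)cc4)cc3)nc12`: 22200 nM

The hydroxy in place of hydrogen gives a 1.6-fold lower number from compound 1 to compound 3 (0.21 log units; within the scatter), so these two compounds sit level on the numbers. Compound 3 reads 22200 nM and compound 2 reads 100000 nM, so compound 3 has the smaller number of these two and belongs with the better-performing end of this small set, without standing apart from compound 1.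

Compound 4 `Oc1cccc2[nH]c(-c3ccc(-c4ccc(-c5ccc(OC(F)(F)F)cc5)cc4)cc3)nc12` has not yet been measured. It differs from compound 3 by one change, (trifluoromethoxy in place of fluoro on an aromatic carbon), which is trifluoromethoxy in place of fluoro on an aromatic carbon, para to a large group.

One measured step makes the same exchange, on the core that lacks the hydroxy: a 2.8-fold higher number from compound 1 to compound 2 (0.45 log units; beyond the scatter). That step is modest but beyond the scatter. Within the data shown here, it is the only precedent, so carrying it over to the hydroxy-bearing compounds is an assumption. On that basis, a modest move toward a higher number is expected in this assay. The expected step is a 2.7-fold higher number from compound 3 to compound 4 (0.43 log units; beyond the scatter). For compound 4 the estimated value is 60000 nM, with an expected range from 30000 nM to 100000 nM.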

Compound 4, concentration for 50% growth inhibition: 3100 nM
Compound 4: the middle estimate sits 19-fold (1.29 log units) above what was measured, outside the stated range (below it).
By their numbers in this assay, from the lowest: compound 4; then compounds 3 and 1 (each within the scatter of the next); then compound 2.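

In this assay, the exchange of fluoro for trifluoromethoxy, para to a large group, turns out to have no fixed direction. With the hydroxy present it gives a 7.2-fold lower number from compound 3 to compound 4 (0.85 log units; beyond the scatter), reversing the step seen on the core without the hydroxy: the same change on two cores in this assay, a 2.8-fold higher number (0.45 log units; beyond the scatter) from compound 1 to compound 2 and a 7.2-fold lower number (0.85 log units; beyond the scatter) from compound 3 to compound 4, 20-fold (1.30 log units) apart, beyond the scatter of two such steps

The hydroxy is just as dependent on its partner, since with the trifluoromethoxy group in place it gives a 32-fold lower number from compound 2 to compound 4 (1.51 log units; beyond the scatter), whereas alongside fluoro its step stayed within the scatter: the same change on two cores in this assay, a 1.6-fold lower number (0.21 log units; within the scatter) from compound 1 to compound 3 and a 32-fold lower number (1.51 log units; beyond the scatter) from compound 2 to compound 4, 20-fold (1.30 log units) apart, beyond the scatter of two such steps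

Across these four compounds, then, the two changes do not act independently, and the 4-fluorophenyl to 4-(trifluoromethoxy)phenyl exchange lowers the number only on the hydroxy-bearing core.

As far as these compounds go, whether the hydroxy itself is required remains open, as a methoxy or an amine in its place could show, and so does whether a chloro or a trifluoromethyl group in place of the trifluoromethoxy would follow the same reversal on that core. The interdependence rests on a single set of four compounds in one cell growth read-out, so how far it extends beyond them, and what lies behind it, stays unsettled.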